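This account rests on a few compounds, and the source may have more. Where it says the series, first, only, none or still open, it means among the compounds named here.

Compound 1 `ClCc1cccc(Cn2cnc3ncnc(Cl)c32)c1`: 3460 nM
Compound 2 `ClCc1ccc(Cn2cnc3nc(Cl)nc(Cl)c32)cc1`: 1900 nM

In a functional assay on NCI-H322M cells (Homo sapiens) for cytotoxicity, read by sulforhodamine B assay, with a stated time of 48 h (a higher number here means a weaker inhibitor of growth, a lower number a stronger inhibitor of growth), compound 2 gives the smaller figure of the two, but its distance from compound 1 lies within the usual scatter, so the two cannot be told apart. Compound 3 `ClCc1ccc(Cn2cnc3ncnc(Cl)c32)cc1` differs from compound 2 by hydrogen in place of chloro on an aromatic carbon, so it keeps one chloro on the shared core. Going by the values given here, no measured pair shows this exact change. Compound 1 also carries a single chloro on the core and gives 3460 nM. On that basis the step of a 1.5-fold higher number from compound 2 to compound 3 (0.17 log units; within the scatter) is expected to stay within the scatter. Compound 3 is therefore expected to give about 2800 nM, between 1200 nM and 7000 nM.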

Compound 3, concentration for total growth inhibition: 3010 nM
Estimate against measurement, compound 3: 1.1-fold (0.03 log units) below, within the range that was stated.
By their numbers in this assay, from the lowest: compounds 2, 3 and 1 (each within the scatter of the next).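

Going by these compounds alone, replacing the chloro between two ring nitrogen atoms with hydrogen gives, in this assay, a 1.6-fold higher number from compound 2 to compound 3 (0.20 log units; within the scatter), the first direct reading at this position. Compound 2 and compound 3 therefore cannot be told apart, so this chloro makes no difference that this measurement can detect. Nothing available explains this result.

As far as these compounds go, it remains open whether an amine or a methoxy group at this position would move the number beyond the scatter. The compounds shown also leave open whether this result would hold in other cell lines.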